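Iodo on the phenyl group of compound 3

The source may hold more compounds than are shown below. What is called first, only, known or untested is meant among the compounds shown, and "the series" means these compounds.

In a functional assay on A-431 cells (Homo sapiens) for cytotoxicity, read by MTT assay, with a stated time of 24 h (a higher number here means a weaker inhibitor, a lower number a stronger inhibitor), compound 3 `COc1ccc(/C=C\C(=O)O)c(OCc2cn(-c3ccccc3)nn2)c1CC=C(C)C` gives 21200 nM, within the scatter of both compound 1 `COc1ccc(/C=C\C(=O)O)c(OCc2cn(-c3ccc(NC(C)=O)cc3)nn2)c1CC=C(C)C` at 23400 nM and compound 2 `COc1ccc(/C=C\C(=O)O)c(OCc2cn(-c3ccccc3F)nn2)c1CC=C(C)C` at 12400 nM. Compound 4 `COc1ccc(/C=C\C(=O)O)c(OCc2cn(-c3ccccc3I)nn2)c1CC=C(C)C` has iodo in place of hydrogen on an aromatic carbon, phenyl to 2-iodophenyl: iodo in place of hydrogen on an aromatic carbon. The closest measured change is a 1.7-fold higher number from compound 2 to compound 3 (0.23 log units; within the scatter), with hydrogen in place of fluoro. The other change on this ring, a 1.1-fold lower number from compound 1 to compound 3 (0.04 log units; within the scatter), with hydrogen in place of acetamido, is also small. For the measured compounds named here, no iodo compound has been measured, so the fluoro comparison is only a rough guide. No shift beyond the scatter is expected in this assay, and the expected step is a 1.3-fold lower number from compound 3 to compound 4 (0.12 log units; within the scatter). The estimate for compound 4 is 16000 nM, with an expected range of 8000 nM to 30000 nM.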

Compound 4, half-maximal inhibitory concentration: 32700 nM
Compound 4: middle estimate off by 2.0-fold (0.31 log units), on the low side, outside the stated range (above it).
By their numbers in this assay, from the lowest: compounds 2, 3, 1 and 4 (each within the scatter of the next, the first and the last beyond it).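

Iodo in place of hydrogen on this aromatic carbon stays within the scatter in this assay (a 1.5-fold higher number from compound 3 to compound 4 (0.19 log units; within the scatter)), as does 2-iodophenyl in place of 4-acetamidophenyl on the aromatic nitrogen (a 1.4-fold higher number from compound 1 to compound 4 (0.15 log units; within the scatter)). The first separation in the series comes between the two halogens, with iodo in place of fluoro (a 2.6-fold higher number from compound 2 to compound 4 (0.42 log units; beyond the scatter)), and that step is modest. Neither compound 2 nor compound 4 separates from compound 3, so the halogen effect rests on this single pair.

From the compounds shown here alone, whether chloro, bromo or an amine on the same carbon would fall between or outside these values remains open. Nothing available accounts for the gap between fluoro and iodo.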